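The compounds below may be only part of what the source reports. "The series", "measured", "known", "first", "only" and "open" are said of these compounds alone.

Measured so far:
compound 1 `O=C(CN(c1ncnc2c1ncn2C1CCCCO1)C1CC1)N[C@@H](CO)C(=O)OCc1ccccc1` — in a functional assay on the whole organism (Tail, strain ICR) with Mus musculus as the target, in the tail flick test, with a stated time of 60 min, at a dose of 25 umol/kg by the oral route (on this read-out lower numbers stand for a weaker effect and higher numbers for a stronger effect at the one dose given), compound 1 gives 46.7%
compound 2 `O=C(O)C[C@H](NC(=O)CN(c1nc(Cl)nc2[nH]cnc12)C1CC1)C(=O)O` — in this assay compound 2 gives 38.9%

Compound 2 stands at the foot of the two numbers shown, but its gap to compound 1 is within the usual scatter and so does not separate them. Compound 3 `NCCCC[C@H](NC(=O)CN(c1nc(Cl)nc2[nH]cnc12)C1CC1)C(=O)O` differs from compound 2 by 3-aminopropyl in place of carboxy on a saturated chain carbon, two bonds along the chain from an amide-type nitrogen and a carbonyl carbon. Among the compounds with values here, no measured pair carries this change, so no step size is known from the data. The expected step is a number 1.1 percentage points higher from compound 2 to compound 3 (within the scatter), which is not beyond the scatter in either direction. Compound 3 is estimated at 40%, with a range of 25% to 58%.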

Compound 3, a percentage reported as activity, at one dose (the size of the read-out at that dose, not a potency): 53.8%
For compound 3 the middle estimate is 13.8 percentage points below the measured one; low and high end bracket the measured number.
By their numbers in this assay, from the lowest: compounds 2, 1 and 3 (each within the scatter of the next, the first and the last beyond it).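

In this assay the saturated chain carbon, two bonds along the chain from an amide-type nitrogen and a carbonyl carbon, responds to 3-aminopropyl in place of carboxy with a number 14.9 percentage points higher from compound 2 to compound 3 (beyond the scatter) and so gives the series its first single-place change that can be read. The position therefore tolerates loss of the carboxy group on this core without a drop in the read-out. Nothing available bears on the reason for this step.

Going by these compounds, whether the carboxylic acid's departure or the amine's arrival carries the step stays open. A plain butyl chain, a shorter aminoalkyl chain or a longer one at this position would separate the two.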